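The source may hold more compounds than are shown below. What is called first, only, known or untested is meant among the compounds shown, and "the series" means these compounds.

Compound 1 `O=S(=O)(Nc1ccc(-c2nc3ccccc3o2)cc1)c1cccc(Cl)c1` and compound 2 `CS(=O)(=O)Nc1ccc(-c2nc3cc(NS(=O)(=O)c4ccc(Cl)s4)ccc3o2)cc1` share a core with compound 3 `C=Cc1ccc(S(=O)(=O)Nc2ccc(-c3nc4ccccc4o3)cc2)cc1`, and all three have been tested in an assay on cells for inhibition of HSP60/HSP10 (Homo sapiens), with a stated time of 60 min; on this read-out higher numbers stand for weaker inhibition and lower numbers for stronger inhibition. Compound 1 gives 54000 nM in this assay. Compound 2 gives 43000 nM in this assay. Compound 3 reaches only the limit of this assay, at > 100000 nM, so for compound 3 the number itself is not known (the limit of > 100000 nM in this assay, at which 1 of the 3 values shown sits). Within the data shown here, the one measured step that touches compound 3 is an at least 1.8-fold higher number from compound 1 to compound 3 (0.26 log units; that floor lies within the scatter).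

Compound 4 `CS(=O)(=O)Nc1ccc(-c2nc3ccccc3o2)cc1` differs from compound 3 in one place: methyl in place of 4-vinylphenyl on a sulfonyl sulfur. Among the measured compounds shown here, no measured step covers this exact change. Compound 2, which also carries a methyl on its sulfonyl sulfur, gives a number in this assay rather than a limit, and the step from compound 1 to compound 3 was too small to settle the direction. Compound 4 is therefore expected to give 60000 nM in this assay, within 20000 nM to 150000 nM, which means an expected step of an at least 1.6-fold lower number from compound 3 to compound 4 (0.22 log units; that floor lies within the scatter), likely within the scatter.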

Compound 4, half-maximal inhibitory concentration: > 100000 nM
Compound 4: no number, only a limit; the forecaster's own chance of this, stated with the estimate: 35%; middle value at least 1.6-fold (0.22 log units) away from the limit.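

In this assay compound 4 gives only a limit, not a number, so methyl on the sulfonyl sulfur yields no readable value, just as 4-vinylphenyl did not: the limit of > 100000 nM in this assay, at which 2 of the 4 values shown sit. The step between compound 3 and compound 4 cannot be read, so this exchange on the sulfonyl sulfur has no measured size. Hydrogen in place of ((5-chlorothiophen-2-yl)sulfonyl)amino on an aromatic carbon gives an at least 2.3-fold higher number from compound 2 to compound 4 (0.36 log units; beyond the scatter), the one readable change here that is beyond the scatter, whereas methyl in place of 3-chlorophenyl gives an at least 1.8-fold higher number from compound 1 to compound 4 (0.26 log units; that floor lies within the scatter), a floor that stays within it.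

Going by these compounds, the actual numbers for compound 3 and compound 4 remain open. Also open, on these data alone, is whether an amine, a carboxylic acid or a longer chain on the sulfonyl sulfur would give a number at all.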